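From 3-bromophenyl to 4-methylphenyl on a shared core

The source may hold more compounds than are shown below. What is called first, only, known or untested is meant among the compounds shown, and "the series" means these compounds.

Measured so far:
- Compound 1 `NC1=NC2(CCOCC2)N(OCCCOc2cccc(Cl)c2Cl)C(N)=N1` gives 440 nM
- Compound 2 `NC1=NC2(CCOCC2)N(OCCCOc2cccc(Br)c2)C(N)=N1` gives 560 nM

Going by the values given here, in a functional assay on HL-60 cells (Homo sapiens) for antiproliferative activity, read by MTT assay, with a stated time of 72 h (on this read-out higher numbers stand for weaker inhibition and lower numbers for stronger inhibition), compound 2 gives 560 nM and so lies within the scatter of compound 1, the only other compound measured. Compound 3 `Cc1ccc(OCCCON2C(N)=NC(N)=NC23CCOCC3)cc1` has not yet been measured. It keeps the shared core, and its change is 4-methylphenyl in place of 3-bromophenyl on an oxygen on a saturated carbon. Among the compounds with values here, one measured step bears on this, though only loosely. Within the data shown here, with 3-bromophenyl in place of 2,3-dichlorophenyl at that same place, the data show a 1.3-fold higher number from compound 1 to compound 2 (0.10 log units; within the scatter) and no measured compound carries 4-methylphenyl. A step beyond the scatter in this assay is therefore not expected. The expected step is a 1.3-fold higher number from compound 2 to compound 3 (0.10 log units; within the scatter) and its direction remains uncertain. For compound 3 the estimated value is 700 nM, with an expected range from 220 nM to 2200 nM.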

Compound 3, half-maximal inhibitory concentration: 2580 nM
The estimate for compound 3 lay 3.7-fold (0.57 log units) below the measured number, outside the stated range (above it).
By their numbers in this assay, from the lowest: compounds 1 and 2 (each within the scatter of the next); then compound 3.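

At this place, on an oxygen on a saturated carbon, the earlier pair had shown no step beyond the scatter, whereas this assay now records a 4.6-fold higher number from compound 2 to compound 3 (0.66 log units; beyond the scatter) for 4-methylphenyl in place of 3-bromophenyl and a 5.9-fold higher number from compound 1 to compound 3 (0.77 log units; beyond the scatter) for 4-methylphenyl in place of 2,3-dichlorophenyl. The aryl group here can therefore shift the number beyond the scatter: the two compounds carrying chlorine or bromine lie within the scatter of each other, and the methyl-bearing compound 3 gives the highest number of the three. No measurement offered here accounts for this step.

Because 4-methylphenyl differs from 3-bromophenyl in both the substituent and its number on the ring, the compounds shown cannot separate those two changes. Going by these compounds, whether 3-methylphenyl or 4-bromophenyl would follow compound 2 or compound 3 remains open, as does the effect of a longer chain.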